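Trifluoromethyl for isopropyl on the sulfonamide ring

The source may hold more compounds than are shown below. What is called first, only, known or untested is meant among the compounds shown, and "the series" means these compounds.

Two compounds in this set carry a measurement. Compound 1 `COc1cccc(Oc2c(NS(=O)(=O)c3ccc(C(C)(C)C)cc3)ncnc2OCCOc2ncc(Br)cn2)c1` gives 0.051 nM in an assay on cells (Endothelial cell) for binding affinity to Endothelin-1 receptor (Sus scrofa); on this read-out lower numbers stand for stronger inhibition and higher numbers for weaker inhibition. Compound 2 `Cc1ccc(-c2c(NS(=O)(=O)c3ccc(C(C)C)cc3)ncnc2OCCOc2ncc(Br)cn2)cc1` gives 0.16 nM in this assay, the higher of the two numbers, and its gap to compound 1 lies beyond the usual scatter. Compound 1 and compound 2 differ in several places at once, so no single change can be read from that pair.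

Compound 3 `Cc1ccc(-c2c(NS(=O)(=O)c3ccc(C(F)(F)F)cc3)ncnc2OCCOc2ncc(Br)cn2)cc1` has not been measured. It differs from compound 2 in one place: trifluoromethyl in place of isopropyl on an aromatic carbon. Within the data shown here, no measured pair shows this exact swap, so nothing in the data fixes the size or direction of the step; the expectation is a small shift, quite possibly within the scatter, with a slight lean toward a higher number. Because compound 2 gives 0.16 nM, compound 3 is expected near 0.3 nM, with a likely range from 0.08 nM to 1 nM. This estimate corresponds to an expected step of a 1.9-fold higher number from compound 2 to compound 3 (0.27 log units; within the scatter), close to the scatter.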

Compound 3, half-maximal inhibitory concentration: 1.4 nM
Beside the measured number, compound 3's estimate is 4.7-fold (0.67 log units) below it; measured number outside the range, above it.
By their numbers in this assay, from the lowest: compound 1; then compound 2; then compound 3.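

Trifluoromethyl in place of isopropyl is the first single change that can be read in this set, and in this assay it gives an 8.8-fold higher number from compound 2 to compound 3 (0.94 log units; beyond the scatter). The result shows that this place on the sulfonamide ring, para to a large group, is sensitive to which group it carries, even though neither group brings a ring, a hydrogen-bond donor, a hydrogen-bond acceptor or a net charge. Nothing measured here accounts for the size of this step, and its cause remains unknown.

The compounds shown give only this one swap at this place, so they cannot say how a nitrile, a methoxy group, an amine or a longer chain would fare there, or whether any of these would stay closer to compound 2 than compound 3 does. Compound 1 carries tert-butyl on this ring but differs from compound 2 and compound 3 in several places, which leaves open whether the same swap would give a similar step on the core of compound 1.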